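Solubility notes: aryl swap on the shared core

The source may report more compounds than this note shows. Statements on the series, on what has been measured and on what is new or still open speak of the compounds shown alone.

Measured so far:
compound 1 `CCOC(=O)c1c(-c2cccc(C(F)(F)F)c2)[nH]c2cc(OC)ccc2c1=O`: 19000 nM
compound 2 `CCOC(=O)c1c(-c2cccc(F)c2)[nH]c2cc(OC)ccc2c1=O`: > 100000 nM

In a physicochemical assay for solubility, in phosphate buffer, at pH 7.4 (on this read-out higher numbers stand for higher solubility and lower numbers for lower solubility), compound 1 gives 19000 nM. Compound 2 stands at the limit of > 100000 nM in this assay, at which 1 of the 2 values shown sits, a limit of the assay rather than a number. Among the compounds with values here, the single measured step, an at least 5.2-fold higher number from compound 1 to compound 2 (0.72 log units; beyond the scatter), concerns the trifluoromethyl group and so does not bear directly on the change to compound 3 `CCOC(=O)c1c(-c2cccs2)[nH]c2cc(OC)ccc2c1=O`, which is thiophen-2-yl in place of 3-fluorophenyl on an aromatic carbon. Within the data shown here, with no step covering this change, the expectation is a shift of about an at least 1.2-fold lower number from compound 2 to compound 3 (0.09 log units; that floor lies within the scatter), hardly beyond the scatter. Compound 3 is therefore expected at 80000 nM, between 25000 nM and 100000 nM, possibly again only as a limit.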

Compound 3, solubility: > 100000 nM
Compound 3: no number, only a limit; the forecaster's own chance of this, stated with the estimate: 50%; middle value at least 1.2-fold (0.09 log units) away from the limit.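

Compound 2 and compound 3 both sit at a limit of the assay rather than at a number, so no step can be read between them. The compounds shown leave open how compound 2 and compound 3 compare in this assay beyond that limit.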